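A few compounds are considered here, and "the series" means these few. Any claim that something is new, unique, unknown or untested is made for them only; others in the source may bear on it.

Among the measured compounds shown here, in a functional assay on HepG2 cells (Homo sapiens) for inhibition, read by sulforhodamine B assay, with a stated time of 72 h (on this read-out lower numbers stand for stronger inhibition and higher numbers for weaker inhibition), compound 2 `C[C@H](Nc1nc(N)nc(N)c1C#N)c1nn(-c2cccc(S(C)(=O)=O)c2)c2cc(F)ccc12` gives 19100 nM, the higher of the two numbers measured so far; its nearest neighbour is compound 1 `C[C@H](Nc1ncnc2[nH]cnc12)c1nn(-c2cccc(S(C)(=O)=O)c2)c2cc(F)ccc12`, which gives 14800 nM, and the step of a 1.3-fold higher number from compound 1 to compound 2 (0.11 log units; within the scatter) concerns the group on the amine nitrogen. Compound 3 `C[C@H](Nc1nc(N)nc(N)c1C#N)c1nn(-c2cccc(S(C)(=O)=O)c2)c2cc(Cl)ccc12` differs from compound 2 by chloro in place of fluoro on an aromatic carbon. For the measured compounds named here, no measured step touches this position, so nothing in the data points to a change in this assay beyond the scatter. Compound 3 is therefore expected to give about 19000 nM, between 8000 nM and 45000 nM, an estimated step of a 1.0-fold lower number from compound 2 to compound 3 (0.00 log units; within the scatter).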

Compound 3, half-maximal inhibitory concentration: 1880 nM
The estimate for compound 3 lay 10-fold (1.00 log units) above the measured number; measured number outside the range, below it.
By their numbers in this assay, from the lowest: compound 3; then compounds 1 and 2 (each within the scatter of the next).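

Replacing fluoro with chloro on this aromatic carbon gives a 10-fold lower number from compound 2 to compound 3 (1.01 log units; beyond the scatter) in this assay. The earlier step, on the amine nitrogen, stayed within the scatter, whereas this exchange of one halogen for another moves the number well beyond it, so the series responds to this position. No measurement shown here accounts for the size of this step. Going by these compounds, whether bromo, methyl or methoxy on this carbon would lower the number further remains open. So does whether chloro would give a similar step in compound 1, which carries a different group on the amine nitrogen.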